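Cytotoxicity series: a hydroxyphenyl analogue of a dichlorophenyl lead

A few compounds are considered here, and "the series" means these few. Any claim that something is new, unique, unknown or untested is made for them only; others in the source may bear on it.

Measured so far:
Compound 1 `O=C1/C(=C\c2c(Cl)cccc2Cl)c2ccccc2N1c1c(Cl)cccc1Cl`: limit of > 100 ug/mL in a functional assay on MCF7 cells (Homo sapiens) for cytotoxicity, read by MTT assay, with a stated time of 72 h; on this read-out lower numbers stand for an effect already at smaller amounts and higher numbers for an effect only at larger amounts of compound.
Compound 2 `O=C1/C(=C\c2cc3ccccc3nc2Cl)c2ccccc2N1c1c(Cl)cccc1Cl`: limit of > 100 ug/mL in this assay.

Compound 1 stands at the assay limit in this assay. Going by the values given here, the same holds for compound 2; both entries are limits and not numbers, so the limit of > 100 ug/mL in this assay, at which 2 of the 2 values shown sit, is all the series shows and no sized step between measured compounds exists.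

Compound 3 `O=C1/C(=C\c2ccc(O)cc2)c2ccccc2N1c1c(Cl)cccc1Cl` differs from compound 1 by 4-hydroxyphenyl in place of 2,6-dichlorophenyl on a double-bonded chain carbon bound to a double-bonded ring carbon. With both values at the limit, no direction can be drawn from the measured data. The step from compound 1 to compound 3 in this assay is expected to be a number no higher from compound 1 to compound 3 (the limit leaves the size open). Compound 3 is estimated at 100 ug/mL, range 40 ug/mL to 300 ug/mL, with a real chance of another limit.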

Compound 3, concentration for half-maximal effect: 20 ug/mL
Compound 3: the middle estimate sits 5.0-fold (0.70 log units) above what was measured; measured number outside the range, below it.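

In this assay, 4-hydroxyphenyl in place of 2,6-dichlorophenyl on a double-bonded chain carbon bound to a double-bonded ring carbon gives an at least 5.0-fold lower number from compound 1 to compound 3 (0.69 log units; beyond the scatter). A change at this position can therefore bring a measurable cytotoxic response on the shared core, which the earlier limits could not show. The full size of the step stays open, and the series remains mostly limits: the limit of > 100 ug/mL in this assay, at which 2 of the 3 values shown sit.

Whether the change depends on the hydroxyl, its place on the ring or the loss of both chlorines remains unresolved. Comparing 4-methoxyphenyl or 4-aminophenyl with 4-hydroxyphenyl would help separate these.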